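This account rests on a few compounds, and the source may have more. Where it says the series, first, only, none or still open, it means among the compounds named here.

In an ADME assay on MT4 cells (Homo sapiens) for cytotoxicity, read by MTT assay, with a stated time of 96 h (on this read-out higher numbers stand for lower toxicity in this test and lower numbers for higher toxicity in this test), compound 1 `Cn1c(-c2ccc(N)cc2)nc2cc(C(F)(F)F)ccc21` gives 20000 nM. Compound 2 `CC(=O)Nc1ccc(-c2nc3cc(C(F)(F)F)ccc3n2C2CCCCC2)cc1` gives 24000 nM in this assay, the top of the two numbers shown, yet its gap to compound 1 lies within the scatter, so the two stand together. Compound 3 `Nc1ccc(-c2nc3cc(C(F)(F)F)ccc3n2C2CCCCC2)cc1` differs from compound 2 by one change: hydrogen in place of acetyl on a nitrogen on an aromatic ring. Among the compounds with values here, no measured pair shows this change on its own, and both measured compounds sit close together in this assay, so compound 3 is expected to show no step beyond the scatter, a 1.2-fold lower number from compound 2 to compound 3 (0.08 log units; within the scatter). Compound 3 is estimated at 20000 nM, within a range from 8000 nM to 50000 nM.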

Compound 3, half-maximal cytotoxic concentration: 44000 nM
The estimate for compound 3 lay 2.2-fold (0.34 log units) below the measured number; measured number inside the range.
By their numbers in this assay, from the lowest: compounds 1, 2 and 3 (each within the scatter of the next, the first and the last beyond it).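

In this assay the change from acetamido to amino on the aromatic ring gives a 1.8-fold higher number from compound 2 to compound 3 (0.26 log units; within the scatter) and so stays within the scatter, which means the acetyl on this nitrogen can go without a clear shift in the read-out. Cyclohexyl in place of methyl on the aromatic nitrogen gives a 2.2-fold higher number from compound 1 to compound 3 (0.34 log units; beyond the scatter) as a modest step beyond the scatter, the first such step here, toward lower toxicity in this test. No evidence at hand accounts for either step. On these data alone, whether an isopropyl on the aromatic nitrogen would fall within this span remains open, as does whether a methanesulfonyl on the other nitrogen would match the acetyl.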